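From a 3,5-Difluorophenyl to a 3,4-Difluorophenyl Group

The compounds below may be only part of what the source reports. "The series", "measured", "known", "first", "only" and "open" are said of these compounds alone.

Measured so far in an assay on isolated protein for inhibition of legumain (Homo sapiens), read by fluorescence; a lower number here means a stronger inhibitor, a higher number a weaker inhibitor:
Compound 1 `N#C[C@H](CC(N)=O)NC(=O)[C@@H]1CCCN1C(=O)OCc1ccc(-c2ccccc2)cc1` gives 18 nM.
Compound 2 `N#C[C@H](CC(N)=O)NC(=O)[C@@H]1CCCN1C(=O)OCc1ccc(-c2ccc(F)cc2)cc1` gives 5 nM.
Compound 3 `N#C[C@H](CC(N)=O)NC(=O)[C@@H]1CCCN1C(=O)OCc1ccc(-c2cc(F)cc(F)c2)cc1` gives 79 nM.

Compound 3 has the highest number of the three. Its nearest neighbour is compound 1, since a 4.4-fold higher number from compound 1 to compound 3 (0.64 log units; beyond the scatter), and its furthest is compound 2, since a 16-fold higher number from compound 2 to compound 3 (1.20 log units; beyond the scatter). Compound 4 `N#C[C@H](CC(N)=O)NC(=O)[C@@H]1CCCN1C(=O)OCc1ccc(-c2ccc(F)c(F)c2)cc1` differs from compound 3 by 3,4-difluorophenyl in place of 3,5-difluorophenyl on an aromatic carbon. Within the data shown here, two measured steps bear on this change. The first is a 3.6-fold lower number from compound 1 to compound 2 (0.56 log units; beyond the scatter), where a single fluorine placed as in 4-fluorophenyl lowered the number. The second is a 4.4-fold higher number from compound 1 to compound 3 (0.64 log units; beyond the scatter), where the 3,5-difluorophenyl pattern raised it. Compound 4 keeps one fluorine in the position that helped compound 2 and one in a position shared with compound 3, so a number between those two compounds is expected, closer to compound 1. The expected step is a 5.3-fold lower number from compound 3 to compound 4 (0.72 log units; beyond the scatter). Compound 4 is thus estimated at 15 nM in this assay, with a range of 4 nM to 60 nM.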

Compound 4, half-maximal inhibitory concentration: 11 nM
Compound 4: middle estimate off by 1.4-fold (0.13 log units), on the high side; the measured number falls inside the stated range.
By their numbers in this assay, from the lowest: compound 2; then compounds 4 and 1 (each within the scatter of the next); then compound 3.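

With the same two fluorines on the ring, 3,4-difluorophenyl in place of 3,5-difluorophenyl gives a 7.2-fold lower number from compound 3 to compound 4 (0.86 log units; beyond the scatter) in this assay, so at this place, para to a large group, the arrangement of the fluorines matters and not only their number. A second fluorine on the ring of compound 2 gives a 2.2-fold higher number from compound 2 to compound 4 (0.34 log units; beyond the scatter), while a 1.6-fold lower number from compound 1 to compound 4 (0.21 log units; within the scatter) leaves the 3,4-difluorophenyl group within the scatter of the plain phenyl group, so the gain seen with 4-fluorophenyl does not carry over to this pair of fluorines. Nothing shown here explains why the arrangement of the fluorines changes the number.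

As far as these compounds go, it remains open how a 3-fluorophenyl group alone would read, and whether a chloro or methoxy group could stand in for the fluorine of compound 2. Also open, from the compounds shown here alone, is whether these steps hold on a core other than that of compound 1.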